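The source may report more compounds than this note shows. Statements on the series, on what has been measured and on what is new or still open speak of the compounds shown alone.

Two compounds share a core built around an imine, with a six-membered carbon-only aromatic ring that carries a small substituent in each case. Compound 1 `COc1ccc(/C=N/Cc2cccnc2)cc1O` carries methoxy and hydroxy groups on that ring, whereas compound 2 `O=[N+]([O-])c1ccc(/C=N/Cc2cccnc2)cc1` carries a nitro group. In a functional assay on the whole organism (strain Swiss albino) with Mus musculus as the target, with a stated time of 4 h (a higher number here means that more compound is needed for the effect, a lower number that less compound is needed), compound 1 gives 300 mg/kg, while compound 2 gives 100 mg/kg, so compound 2 stands at the lower of the two numbers and needs the smaller dose. The next compound, compound 3 `C(=N/Cc1cccnc1)\c1ccccc1`, keeps the shared core but loses the nitro group: hydrogen in place of nitro on an aromatic carbon. Going by the values given here, no measured pair shows what stripping a substituent from this ring does, so the expectation rests on the two numbers alone. Because compound 2 gives 100 mg/kg and compound 1 gives 300 mg/kg, a modest rise in dose toward the middle is expected, the step from compound 2 to compound 3 being a 2.0-fold higher number from compound 2 to compound 3 (0.30 log units; within the scatter). Compound 3 is estimated at 200 mg/kg, likely between 100 mg/kg and 400 mg/kg.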

Compound 3, minimum effective dose: 100 mg/kg
Estimate against measurement, compound 3: 2.0-fold (0.30 log units) above; the measured number falls inside the stated range.
By their numbers in this assay, from the lowest: compounds 2 and 3 (each within the scatter of the next); then compound 1.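

Putting hydrogen in place of nitro on this aromatic carbon, para to a group of 9 heavy atoms, gives no change at the digits printed from compound 2 to compound 3 (within the scatter) in this assay. The nitro group can therefore be removed from this position with no change in the dose beyond the usual scatter of this kind of measurement. Going by these compounds alone, the two earlier compounds offered no comparison of a single change, so this is the first direct reading of one group at this position, though nothing measured here explains the result.

As far as these compounds go, it remains open whether an amine, a carboxylic acid or a chlorine atom on this same aromatic carbon would shift the dose in either direction. From the compounds shown here alone, it is also open whether the nitro group would behave the same way on another carbon of the ring.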